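The compounds below may be only part of what the source reports. "The series", "measured", "known", "first", "only" and "open" are said of these compounds alone.

In a functional assay on MCF7 cells (Homo sapiens) for cytotoxicity, read by sulforhodamine B assay, with a stated time of 72 h (a higher number here means a weaker inhibitor, a lower number a stronger inhibitor), compound 1 `CCOC(=O)c1nn(-c2ccc(OC)cc2)/c(=N/c2nc(-c3c(C)n(C)n(-c4ccccc4)c3=O)cs2)s1` gives 15900 nM. Compound 2 `Cc1c(-c2csc(/N=C3\S/C(=C\c4ccc(Cl)cc4)C(=O)N3c3ccccc3)n2)c(=O)n(-c2ccccc2)n1C` reaches only the limit of the assay, > 100000 nM. Compound 3 `Cc1c(-c2csc(/N=C3\S/C(=C\c4ccc(N(C)C)cc4)C(=O)N3c3ccccc3)n2)c(=O)n(-c2ccccc2)n1C` likewise reaches only the assay limit, > 100000 nM. The step from compound 2 to compound 3, a step that the two limits leave unreadable from compound 2 to compound 3, cannot be read in size because the limit of > 100000 nM in this assay, at which 2 of the 3 values shown sit, hides both ends. Compound 3 thus stands at the limit, as does compound 2, with compound 1 the only one of the three that gives a number. Compound 4 `Cc1ccc(/C=C2\S/C(=N\c3nc(-c4c(C)n(C)n(-c5ccccc5)c4=O)cs3)N(c3ccccc3)C2=O)cc1` differs from compound 3 by methyl in place of dimethylamino on an aromatic carbon. Among the measured compounds shown here, no measured step bears directly on this change, and the single measured step is unreadable. Compound 4 is therefore expected to stay at or near the limit, an estimated 100000 nM with a range from 30000 nM to 300000 nM, meaning an expected step of a number no higher from compound 3 to compound 4 (the limit leaves the size open).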

Compound 4, half-maximal inhibitory concentration: > 100000 nM
Compound 4: no number, only a limit; the forecaster's own chance of this, stated with the estimate: 70%; the middle value lies on the limit itself.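

Compound 4 also gives only a limit, so no step from compound 2 or compound 3 to compound 4 can be read: the limit of > 100000 nM in this assay, at which 3 of the 4 values shown sit.

From the compounds shown here alone, whether chloro, dimethylamino and methyl differ at all in their effect on cytotoxicity stays open.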